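A few compounds are considered here, and "the series" means these few. Any claim that something is new, unique, unknown or untested is made for them only; others in the source may bear on it.

The measured compounds:
Compound 1 `CCCCSc1nc(N)nc2c1ncn2/C=C1/CC1(CO)CO`, which in an ADME assay on CCRF-HSB-2 cells (Homo sapiens) for cytotoxicity, with a stated time of 7 days (a lower number here means that less compound is tolerated, a higher number that more compound is tolerated), gives 89000 nM.
Compound 2 `CCOc1nc(N)nc2c1ncn2/C=C1/CC1(CO)CO`, for which this assay reports only a limit, > 20000 nM.
Compound 3 `CCCCCCOc1nc(N)nc2c1ncn2/C=C1/CC1(CO)CO`, for which this assay again reports only a limit, > 20000 nM.

Compound 3 therefore stands not at a number but at a limit, and only compound 1 has a plain value in this set; the other two, compound 3 among them, sit at the limit described by the limit of > 20000 nM in this assay, at which 2 of the 3 values shown sit. The new compound 4 `CNc1nc(N)nc2c1ncn2/C=C1/CC1(CO)CO` differs from compound 3 in one place: methylamino in place of hexyloxy on an aromatic carbon.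

Two measured steps end at compound 3: a step that the limit leaves unreadable from compound 1 to compound 3 and a step that the two limits leave unreadable from compound 2 to compound 3. Neither gives a readable size, because a step that the limit leaves unreadable from compound 1 to compound 3 and a step that the two limits leave unreadable from compound 2 to compound 3 both run into the limit. Going by the values given here, no step can therefore be expected from them beyond the scatter in either direction, and nothing in the three values points away from the limit. Compound 4 is expected in this assay to give about 60000 nM, within a range from 15000 nM to 300000 nM. The step expected for compound 4 is a step that the limit leaves unreadable from compound 3 to compound 4.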

Compound 4, half-maximal cytotoxic concentration: > 20000 nM
Compound 4: only a limit was reported (the forecaster's own chance of this, stated with the estimate: 60%); the middle value lies beyond the limit too.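

Going by these compounds alone, compound 4 also reports only a limit, so no step to it from compound 1, compound 2 or compound 3 can be read: the limit of > 20000 nM in this assay, at which 3 of the 4 values shown sit. The compounds shown leave open whether exchanging the group on this aromatic carbon changes the tolerated concentration at all, and by how much.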